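Aryl swaps on the alkyne: from compound 3 to compound 4

This account rests on a few compounds, and the source may have more. Where it says the series, first, only, none or still open, it means among the compounds named here.

Measured so far in a functional assay on A375-C5 cells (Homo sapiens) for inhibition, read by sulforhodamine B assay, with a stated time of 48 h; a higher number here means a weaker inhibitor of growth, a lower number a stronger inhibitor of growth:
- compound 1, `COC(=O)c1sc2cc(C#Cc3ccccn3)cnc2c1N`: 13900 nM
- compound 2, `COC(=O)c1sc2cc(C#Cc3ccc(N)cc3)cnc2c1N`: 4800 nM
- compound 3, `COC(=O)c1sc2cc(C#Cc3ccccc3F)cnc2c1N`: > 150000 nM

Compound 3 carries a 2-fluorophenyl on the triple-bonded carbon. In this assay compound 3 gives only a limit, > 150000 nM, so no number is known for it; it sits at the limit of > 150000 nM in this assay, at which 1 of the 3 values shown sits. Against the two aryl groups already measured this limit is a large step: an at least 10-fold higher number from compound 1 to compound 3 (1.03 log units; beyond the scatter) and an at least 31-fold higher number from compound 2 to compound 3 (1.49 log units; beyond the scatter). Between the other two, a 2.9-fold lower number from compound 1 to compound 2 (0.46 log units; beyond the scatter).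

Compound 4, `COC(=O)c1sc2cc(C#Cc3cccc(OC)c3)cnc2c1N`, is the next step from compound 3: 3-methoxyphenyl in place of 2-fluorophenyl on a triple-bonded carbon. Within the data shown here, the steps that bear on it are the two ending at compound 3, both large and both in the direction of a higher number when 2-fluorophenyl enters. Leaving 2-fluorophenyl again is therefore expected to bring the number back down, by a large step, toward the region where compound 1 and compound 2 sit, though a limit remains possible. For compound 4 the expected value is 20000 nM, with a range of 5000 nM to 150000 nM. This estimate corresponds to an at least 7.5-fold lower number from compound 3 to compound 4 (0.87 log units; beyond the scatter).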

Compound 4, concentration for 50% growth inhibition: > 75000 nM
Compound 4: only a limit was reported (the forecaster's own chance of this, stated with the estimate: 30%); middle value at least 3.7-fold (0.57 log units) away from the limit.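

In this assay compound 4 is reported only as a limit: the limit of > 75000 nM in this assay, at which 1 of the 4 values shown sits. Replacing pyridin-2-yl or 4-aminophenyl on the triple-bonded carbon with 3-methoxyphenyl also gives a higher number, so 2-fluorophenyl is not alone in this: an at least 5.3-fold higher number from compound 1 to compound 4 (0.73 log units; beyond the scatter), and an at least 15-fold higher number from compound 2 to compound 4 (1.19 log units; beyond the scatter). The step between compound 3 and compound 4 cannot be read, as both are limits, which leaves 2-fluorophenyl and 3-methoxyphenyl unordered, and among the four groups on this carbon only pyridin-2-yl and 4-aminophenyl give a number.

Still open, on these data alone, is whether the amine of compound 2 itself accounts for its place, which an acetamide or a hydroxyl group on the same phenyl would test. Also open, as far as these compounds go, is where the true values of compound 3 and compound 4 lie beyond their limits.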